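A new group on the amide nitrogen of compound 2

The compounds below may be only part of what the source reports. "The series", "measured", "known", "first", "only" and "open" are said of these compounds alone.

In a functional assay on HT-29 cells (Homo sapiens) for cytotoxicity, read by MTT assay, with a stated time of 72 h (on this read-out lower numbers stand for stronger inhibition and higher numbers for weaker inhibition), compound 1 `COc1ccc(NC(=O)CN2CCN(c3nnc(Cc4ccccc4)c4ccccc34)CC2)cc1OC` gives 145000 nM, compound 2 `Cc1cccc(Cl)c1NC(=O)CN1CCN(c2nnc(Cc3ccccc3)c3ccccc23)CC1` gives 53600 nM and compound 3 `Cc1cccc(Cl)c1NC(=O)CN1CCN(c2nnc(Cc3ccncc3)c3ccccc23)CC1` gives 22600 nM. Compound 2 therefore holds the second highest of the three numbers. Compound 4 `O=C(CN1CCN(c2nnc(Cc3ccccc3)c3ccccc23)CC1)Nc1ccc(F)c(Cl)c1` changes one group of compound 2: 3-chloro-4-fluorophenyl in place of 2-chloro-6-methylphenyl on an amide-type nitrogen. Among the measured compounds shown here, the only measured change at this amide-type nitrogen is a 2.7-fold lower number from compound 1 to compound 2 (0.43 log units; beyond the scatter), which is modest. The other measured step, a 2.4-fold lower number from compound 2 to compound 3 (0.38 log units; beyond the scatter), lies at a different place and offers little guidance. For the measured compounds named here, no measured compound carries the entering group, so no clear direction can be expected. The estimated change, a 1.1-fold lower number from compound 2 to compound 4 (0.03 log units; within the scatter), is expected to be small. Compound 4 is expected near 50000 nM, within an estimated range of 16000 nM to 150000 nM.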

Compound 4, half-maximal inhibitory concentration: 13300 nM
Compound 4: middle estimate off by 3.8-fold (0.58 log units), on the high side, and the stated range ends above it.
By their numbers in this assay, from the lowest: compounds 4 and 3 (each within the scatter of the next); then compound 2; then compound 1.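

In this assay, among the compounds shown here, the amide-type nitrogen proves able to carry a wider spread than the earlier compounds showed: 3-chloro-4-fluorophenyl brings a 4.0-fold lower number from compound 2 to compound 4 (0.61 log units; beyond the scatter) and also an 11-fold lower number from compound 1 to compound 4 (1.04 log units; beyond the scatter) in this series. The 2-chloro-6-methylphenyl and 3-chloro-4-fluorophenyl groups have the same count of heavy atoms, so that count does not separate them. Nothing measured here accounts for either step. On these data alone, whether the chlorine or the fluorine of the entering group matters more remains open. So does how a morpholine or a carboxylic acid on the phenyl ring at this nitrogen would read.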